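The source may hold more compounds than are shown below. What is called first, only, known or untested is meant among the compounds shown, and "the series" means these compounds.

Working notes on the series. Going by the values given here, in an ADME assay on L6 cells (Rattus norvegicus) for cytotoxicity, read by resazurin assay, with a stated time of 70 h (a lower number here means a stronger inhibitor, a higher number a weaker inhibitor), compound 1 (`CC(=O)Oc1ccc2c(c1)C(C)=CC(C)(C)N2Cc1cccc(C#N)c1`) gives 31000 nM and compound 2 (`CC(=O)Oc1ccc2c(c1)C(C)=CC(C)(C)N2Cc1cccc(C(F)(F)F)c1`) gives 27000 nM, so compound 1 stands level, within the scatter, with the only other number available. Compound 3 (`CC(=O)Oc1ccc2c(c1)C(C)=CC(C)(C)N2Cc1ccc(F)cc1`) keeps the shared core and differs from compound 1 at one place: 4-fluorophenyl in place of 3-cyanophenyl on a saturated chain carbon bound to a nitrogen on an aromatic ring in a ring. This is 4-fluorophenyl in place of 3-cyanophenyl on a saturated chain carbon bound to a nitrogen on an aromatic ring in a ring. Among the compounds with values here, the one measured step that bears on this, a 1.1-fold lower number from compound 1 to compound 2 (0.06 log units; within the scatter), also removes the cyano group, and it stays within the scatter. Within the data shown here, no measured compound yet carries 4-fluorophenyl, so the basis is thin. The expectation in this assay is no step beyond the scatter in either direction, an estimated 1.1-fold lower number from compound 1 to compound 3 (0.04 log units; within the scatter). For compound 3 the estimated value is 28000 nM, with an expected range of 14000 nM to 55000 nM.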

Compound 3, half-maximal inhibitory concentration: 29000 nM
The estimate for compound 3 lay 1.0-fold (0.02 log units) below the measured number; low and high end bracket the measured number.
By their numbers in this assay, from the lowest: compounds 2, 3 and 1 (each within the scatter of the next).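

In this assay, 4-fluorophenyl in place of 3-cyanophenyl gives a 1.1-fold lower number from compound 1 to compound 3 (0.03 log units; within the scatter), so the nitrile can leave this place on the saturated chain carbon with no step beyond the scatter, even when the phenyl substituent differs in both identity and ring number. The earlier step, a 1.1-fold lower number from compound 1 to compound 2 (0.06 log units; within the scatter), covered only a swap of one group for another at the same place on the aromatic ring. No measurement here explains why the number holds across these groups.

As far as these compounds go, whether this flat picture extends to groups of another kind remains open, such as an amine or a carboxylic acid on the phenyl ring, or a longer chain between the ring and the nitrogen. The shared core also stays constant throughout, so its contribution to these numbers cannot be read from the compounds shown.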